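The source may hold more compounds than are shown below. What is called first, only, known or untested is meant among the compounds shown, and "the series" means these compounds.

Measured so far in a functional assay on MCF7 cells (Homo sapiens) for inhibition, read by CCK-8 assay, with a stated time of 48 h; a higher number here means a weaker inhibitor, a lower number a stronger inhibitor:

Compound 1, `COc1cc(-c2ccnc3cc(-c4c[nH]c5ccccc45)nn23)cc(OC)c1OC`: 85 nM
Compound 2, `COc1cc(-c2ccnc3cc(-c4ccccc4)nn23)cc(OC)c1OC`: 254 nM
Compound 3, `COc1ccc(-c2cc3nccc(-c4cc(OC)c(OC)c(OC)c4)n3n2)cc1`: 125 nM

Compound 3 holds the second highest of the three numbers in this assay: its gap to compound 1 lies within the scatter, while the step of a 2.0-fold lower number from compound 2 to compound 3 (0.31 log units; beyond the scatter) lies beyond it. Compound 4, `COc1cc(-c2ccnc3cc(-c4ccc(F)cc4)nn23)cc(OC)c1OC`, differs from compound 3 in one place: fluoro in place of methoxy on an aromatic carbon. Of the measured steps, only a 2.0-fold lower number from compound 2 to compound 3 (0.31 log units; beyond the scatter) bears on this position, and it was modest. A fluoro at the same place is expected to land between compound 2 and compound 3, so the step of a 1.4-fold higher number from compound 3 to compound 4 (0.13 log units; within the scatter) is expected to be small, toward a higher number. Compound 4 is therefore estimated at 170 nM, within 90 nM to 330 nM.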

Compound 4, half-maximal inhibitory concentration: 1280 nM
For compound 4 the middle estimate is 7.5-fold (0.88 log units) below the measured one, outside the stated range (above it).
By their numbers in this assay, from the lowest: compounds 1 and 3 (each within the scatter of the next); then compound 2; then compound 4.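

In this assay, going by these compounds alone, the change from 4-methoxyphenyl to 4-fluorophenyl is a large one (a 10-fold higher number from compound 3 to compound 4 (1.01 log units; beyond the scatter)), so this position is far more sensitive than the earlier compounds showed. Set against the hydrogen of compound 2, fluoro and methoxy pull in opposite directions (a 5.0-fold higher number from compound 2 to compound 4 (0.70 log units; beyond the scatter); a 2.0-fold lower number from compound 2 to compound 3 (0.31 log units; beyond the scatter)), and the step from the 1H-indol-3-yl group is wider still (a 15-fold higher number from compound 1 to compound 4 (1.18 log units; beyond the scatter)). Nothing available explains this difference. Open, going by these compounds, is how a chloro, hydroxy or amino group would behave at this place, and whether a fluoro would cost as much on a different ring.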